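Phenyl to Furan on a Core Without Measurable Potency

The compounds below may be only part of what the source reports. "The series", "measured", "known", "first", "only" and "open" are said of these compounds alone.

Compound 1, `CCCCCn1c(-c2ccccc2)nc2c(N)ccnc21`, was tested in an assay on isolated protein for inhibition of high affinity 3',5'-cyclic-AMP phosphodiesterase 7A (Homo sapiens), read by cAMP accumulation, with a stated time of 20 min; a lower number here means a stronger inhibitor, a higher number a weaker inhibitor. In this assay compound 1 reaches only a limit, > 200000 nM, not a number. Compound 2, `CCCCCn1c(-c2ccco2)nc2c(N)ccnc21`, carries furan-2-yl in place of phenyl on an aromatic carbon. In this assay compound 2 likewise stops at a limit, > 200000 nM. The step that the two limits leave unreadable from compound 1 to compound 2 therefore cannot be sized, because of the limit of > 200000 nM in this assay, at which 3 of the 3 values shown sit.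

Compound 3, `CCCCCn1c(-c2ccccc2)nc2c(NCc3ccccc3)nccc21`, differs from compound 1 by more than one place, and the difference between the two cores is not broken down here. In this assay compound 3 again gives only a limit, > 200000 nM.

Compound 4, `CCCCCn1c(-c2ccco2)nc2c(NCc3ccccc3)nccc21`, is not yet measured. Relative to compound 3 it carries furan-2-yl in place of phenyl on an aromatic carbon, the same change that turns compound 1 into compound 2. For compound 4 the expected step is a step that the limit leaves unreadable from compound 3 to compound 4, and this expectation rests on compound 1 and compound 2 both sitting at the limit, as the limit of > 200000 nM in this assay, at which 3 of the 3 values shown sit, states. Since every measured value here is a limit and none is a number, the change cannot be shown to help or to hurt, and compound 4 is expected to stay at the limit too.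

For compound 4 the estimate in this assay is 300000 nM, with a range from 50000 nM to 2000000 nM.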

Compound 4, half-maximal inhibitory concentration: > 200000 nM
Compound 4 ended at the assay's limit; the forecaster's own chance of this, stated with the estimate: 90%; the middle value does not contradict the limit.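

Compound 3 and compound 4 both give only a limit in this assay, so swapping phenyl for furan-2-yl cannot be sized in this pair, because neither result is a number: the limit of > 200000 nM in this assay, at which 4 of the 4 values shown sit.

The compounds shown leave open whether phenyl or furan-2-yl gives the stronger inhibitor, and whether any compound with these cores reaches a measurable number in this assay.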